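The source may report more compounds than this note shows. Statements on the series, on what has been measured and on what is new or still open speak of the compounds shown alone.

Working notes on the series.

Three esters of the same core have been measured in a physicochemical assay for lipophilicity; a lower number here means a more polar compound, a higher number a more lipophilic compound. Compound 1 `C=CC(C)OC(=O)/C=C(C)/C=C/CC(C)CCCC(C)(C)OC` gives 5.94 and stands lowest of the three. Compound 2 `CC(/C=C/CC(C)CCCC(C)(C)OC(C)C)=C\C(=O)OC(C)C` gives 6.9, and compound 3 `CSC(C)(C)CCCC(C)C/C=C/C(C)=C/C(=O)OC(C)C` gives 6.77; both of these sit higher than compound 1 by margins beyond the scatter. For the measured compounds named here, the one step between compounds that differ in a single place, a number 0.13 log units lower from compound 2 to compound 3 (within the scatter), concerns the saturated chain end only and leaves this assay essentially unchanged.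

Compound 4 `CCNC(=O)/C=C(C)/C=C/CC(C)CCCC(C)(C)OC` has not yet been measured in this assay. It differs from compound 1 in a single place: ethylamino in place of (1-methylprop-2-en-1-yl)oxy on a carbonyl carbon. Going by the values given here, no measured pair touches the carbonyl carbon, so the step from compound 2 to compound 3 does not bear on this change, and there is no measured step to lean on. Given that the leaving group counts more heavy atoms than the entering group and that the entering group brings a hydrogen-bond donor while the leaving group carried none, a move toward the polar side of this assay is expected, and a large one. The expected step is a number 1.64 log units lower from compound 1 to compound 4 (beyond the scatter). Compound 4 is therefore estimated at 4.3, with a range from 3.6 to 5.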

Compound 4, partition coefficient: 4.04
Beside the measured number, compound 4's estimate is 0.26 log units above it; the range from low to high includes it.
By their numbers in this assay, from the lowest: compound 4; then compound 1; then compounds 3 and 2 (each within the scatter of the next).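

In this assay, the carbonyl carbon now has its first measured step: ethylamino in place of (1-methylprop-2-en-1-yl)oxy gives a number 1.90 log units lower from compound 1 to compound 4 (beyond the scatter). For the compounds shown here, this contrasts with the only earlier step, a number 0.13 log units lower from compound 2 to compound 3 (within the scatter), which concerned the saturated chain end and so gave no reading at the carbonyl carbon, where the earlier compounds all carried esters. Nothing available on the series accounts for the size of the new step, so the number stands as an observation only.

The step replaces the linking atom and the carbon group on it together, and the compounds shown do not separate the two: a (1-methylprop-2-en-1-yl)amino group on the core of compound 1, or an isopropylamino group on the core of compound 2, would hold the carbon group nearly fixed while changing only the link. Also open, from the compounds shown here alone, is how far the number moves with a dimethylamino group on the same carbonyl carbon, which has no hydrogen on its nitrogen, or with a longer chain on the nitrogen than ethyl.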